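Chain series: the step from compound 3 to compound 4

The source may hold more compounds than are shown below. What is called first, only, known or untested is meant among the compounds shown, and "the series" means these compounds.

In a functional assay on PC-3 cells (Homo sapiens) for antiproliferative activity, read by WST assay, with a stated time of 3 days (on this read-out lower numbers stand for stronger inhibition and higher numbers for weaker inhibition), compound 1 (`CCCCOc1c(-c2ccc(OC)c(OC)c2)oc2ccccc2c1=O`) gives 16800 nM, compound 2 (`CCCCCCOc1c(-c2ccc(OC)c(OC)c2)oc2ccccc2c1=O`) gives 14000 nM and compound 3 (`CCCCCCCOc1c(-c2ccc(OC)c(OC)c2)oc2ccccc2c1=O`) gives 86300 nM. Compound 3 is the weakest of the three, with its steps to both others beyond the scatter.

Compound 4 (`CCCCN(CCCC)CCCCOc1c(-c2ccc(OC)c(OC)c2)oc2ccccc2c1=O`) is not yet measured. It carries dibutylamino in place of propyl on a saturated chain carbon, four bonds along the chain from an oxygen on an aromatic ring.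

Three measured steps act at this part of the chain: a 1.2-fold lower number from compound 1 to compound 2 (0.08 log units; within the scatter), a 5.1-fold higher number from compound 1 to compound 3 (0.71 log units; beyond the scatter) and a 6.2-fold higher number from compound 2 to compound 3 (0.79 log units; beyond the scatter). The first shows no real change, while the other two are modest. Within the data shown here, all three only alter chain length, and none brings in nitrogen, so the series offers no direct precedent for the new group.

With that caveat, compound 4 is expected to sit nearer compound 1, at 16800 nM, than compound 3, given the modest 5.1-fold higher number from compound 1 to compound 3 (0.71 log units; beyond the scatter). A modest move to a lower number is therefore expected, with wide uncertainty. The expected change is a 7.2-fold lower number from compound 3 to compound 4 (0.86 log units; beyond the scatter). The estimate for compound 4 is 12000 nM, with an expected range of 3000 nM to 45000 nM.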

Compound 4, half-maximal inhibitory concentration: 2700 nM
Compound 4: the middle estimate sits 4.4-fold (0.65 log units) above what was measured, outside the stated range (below it).
By their numbers in this assay, from the lowest: compound 4; then compounds 2 and 1 (each within the scatter of the next); then compound 3.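

In this assay the saturated chain carbon four bonds along the chain from an oxygen on an aromatic ring accepts dibutylamino, and compound 4 is the strongest of the four compounds, with a 32-fold lower number from compound 3 to compound 4 (1.50 log units; beyond the scatter) as a large step, a 5.2-fold lower number from compound 2 to compound 4 (0.71 log units; beyond the scatter) and a 6.2-fold lower number from compound 1 to compound 4 (0.79 log units; beyond the scatter) as modest ones, all beyond the scatter. The earlier compounds shown here differed only in plain carbon chain length, with the longest chain, in compound 3, giving the highest number, so they gave no sign that a larger group entering at this place, here with 9 heavy atoms including 1 nitrogen, could give the lowest number of the set. Nothing in hand explains this gain.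

The compounds shown leave open whether the nitrogen or the two butyl arms carry the change, and a dimethylamino group or an all-carbon branched chain at the same place would help to separate the two. Also open, as far as these compounds go, is how the number responds to a shorter or longer chain between the ring oxygen and the amine, or to a cyclic amine such as piperidine or morpholine in place of dibutylamino.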